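The source may report more compounds than this note shows. Statements on the series, on what has been measured and on what is new or still open speak of the compounds shown alone.

Measured so far in a functional assay on B16 cells (Mus musculus) for cytotoxicity, read by CCK-8 assay, with a stated time of 24 h; a lower number here means a stronger inhibitor, a higher number a weaker inhibitor:
compound 1 `COc1ccc(-c2nc(N)c(Oc3ccccc3OC)c(Cl)n2)cc1` gives 47800 nM
compound 2 `COc1ccccc1Oc1c(N)nc(-c2ccc(F)cc2)nc1Cl` gives 2990 nM
compound 3 `COc1ccccc1Oc1c(N)nc(-c2cccc(Br)c2)nc1Cl` gives 24600 nM

Two steps place compound 3 in this small set. One is a 1.9-fold lower number from compound 1 to compound 3 (0.29 log units; within the scatter) and the other is an 8.2-fold higher number from compound 2 to compound 3 (0.92 log units; beyond the scatter), so its number sits with that of compound 1 and well away from that of compound 2.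

The next compound is compound 4 `COc1ccccc1Oc1c(N)nc(-c2ccc(I)cc2)nc1Cl`, which keeps the shared core and changes one group: 4-iodophenyl in place of 3-bromophenyl on an aromatic carbon. In plain terms, 4-iodophenyl takes the place of 3-bromophenyl on an aromatic carbon between two ring nitrogen atoms.

Among the measured compounds shown here, no measured step makes this exact change. The closest evidence is the swap of 4-fluorophenyl for 3-bromophenyl, an 8.2-fold higher number from compound 2 to compound 3 (0.92 log units; beyond the scatter), and the new step partly reverses it. The group on this ring can matter a great deal, as a 16-fold lower number from compound 1 to compound 2 (1.20 log units; beyond the scatter) shows. Still, compound 1 argues against any simple trend, since its 4-methoxyphenyl gives 47800 nM. For the measured compounds named here, no measured compound carries iodine, so only a partial return towards lower numbers is expected, and the size remains uncertain.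

The expected change is a 2.7-fold lower number from compound 3 to compound 4 (0.44 log units; beyond the scatter) by estimate, a modest drop at most likely. For compound 4 the estimated value in this assay is 9000 nM, with an expected range from 2500 nM to 32000 nM in this assay.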

Compound 4, half-maximal inhibitory concentration: 5400 nM
Compound 4: the middle estimate sits 1.7-fold (0.22 log units) above what was measured, and the stated range covers the measured number.
By their numbers in this assay, from the lowest: compounds 2 and 4 (each within the scatter of the next); then compounds 3 and 1 (each within the scatter of the next).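

In this assay, the change from 3-bromophenyl to 4-iodophenyl gives a 4.6-fold lower number from compound 3 to compound 4 (0.66 log units; beyond the scatter), the first sign that a heavy halogen on this ring can go with a low number, although this step changes both the halogen and its place on the ring. Iodo in place of fluoro gives a 1.8-fold higher number from compound 2 to compound 4 (0.26 log units; within the scatter), so the assay cannot tell these two 4-halophenyl groups apart, while iodo in place of methoxy gives an 8.9-fold lower number from compound 1 to compound 4 (0.95 log units; beyond the scatter), a second halogen at that ring position that stands clearly apart from the 4-methoxyphenyl of compound 1. Nothing measured here explains why these groups differ in this way.

The compounds shown leave open whether the higher number of compound 3 comes from bromine itself or from where it sits, a question that bromine and iodine compared at the same ring position would settle. They also leave open how this position responds to groups of a quite different kind, such as an amine or a carboxylic acid on the phenyl ring, or to a phenyl ring with no added group at all.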